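Nitrophenyl isomers in the cytotoxicity read-out

This account rests on a few compounds, and the source may have more. Where it says the series, first, only, none or still open, it means among the compounds named here.

In an ADME assay on MT4 cells (Homo sapiens) for cytotoxicity, read by MTT assay, with a stated time of 5 days (a higher number here means that more compound is tolerated, a lower number that less compound is tolerated), compound 1 (`COc1cc2nc([S+]([O-])CC(=O)Nc3ccc([N+](=O)[O-])cc3)nc(Nc3c(C)cc(/C=C/C#N)cc3C)c2cc1OC`) gives 189000 nM. Compound 2 (`COc1cc2nc([S+]([O-])CC(=O)Nc3cccc([N+](=O)[O-])c3)nc(Nc3c(Cl)cc(/C=C/C#N)cc3Cl)c2cc1OC`) stands at a limit of the assay, >= 83200 nM, and has no exact number.

Compound 3 (`COc1cc2nc([S+]([O-])CC(=O)Nc3ccc([N+](=O)[O-])cc3)nc(Nc3c(Cl)cc(/C=C/C#N)cc3Cl)c2cc1OC`) carries 4-nitrophenyl in place of 3-nitrophenyl on an amide-type nitrogen. The two have the same atoms, joined differently. Going by the values given here, no measured pair shows this change on its own, so any expectation for it is loose. Among the compounds with values here, the size expected in this assay is small, with a slight upward direction at most, since the only exact number is that of compound 1 at 189000 nM. The expected change is a step that the limit leaves unreadable from compound 2 to compound 3, which is no more than the usual scatter. For compound 3 the estimated value is 120000 nM, with an expected range of 50000 nM to 260000 nM.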

Compound 3, half-maximal cytotoxic concentration: 92800 nM
Compound 3: middle estimate off by 1.3-fold (0.11 log units), on the high side; the range from low to high includes it.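

In this assay, going by these compounds alone, compound 3 gives the first exact number for the chlorine-bearing group on a nitrogen on an aromatic ring, and with 4-nitrophenyl common to both compounds it allows one readable comparison: a 2.0-fold lower number from compound 1 to compound 3 (0.31 log units; beyond the scatter). Replacing the group that has only carbon and nitrogen with the chlorine-bearing group thus gives a modest drop in the tolerated concentration, shown by this single pair. The change from 3-nitrophenyl to 4-nitrophenyl on an amide-type nitrogen still cannot be read, because compound 2 stands at a limit: the limit of >= 83200 nM in this assay, at which 1 of the 3 values shown sits.

From the compounds shown here alone, whether the chlorine-bearing group gives the same step alongside 3-nitrophenyl remains open. Also open, going by these compounds, is how the number would move with an amine or a carboxylic acid in place of the nitro group on the phenyl ring.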